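Amide substituent swap on a kinase inhibitor scaffold

This account rests on a few compounds, and the source may have more. Where it says the series, first, only, none or still open, it means among the compounds named here.

Compound 1, `CNS(=O)(=O)c1ccccc1Nc1cc(-c2ccc3ccn(C)c3c2)c2nccnc2c1`: in an assay on lysate for inhibition of 6-phosphofructo-2-kinase/fructose-2,6-bisphosphatase 3 (Homo sapiens), with stated times of 0.5 min and 45 min (a lower number here means a stronger inhibitor, a higher number a weaker inhibitor), compound 1 gives > 100000 nM, which is a limit of the assay.
Compound 2, `Cn1cc(CNC(=O)c2ccncc2Nc2cc(-c3ccc4ccn(C)c4c3)c3nccnc3c2)cn1`: in this assay compound 2 gives 75900 nM.

Compound 2 holds the only number shown; the other value sits at the limit of > 100000 nM in this assay, at which 1 of the 2 values shown sits. Compound 3, `CC(=O)N1CCC(NC(=O)c2ccncc2Nc2cc(-c3ccc4ccn(C)c4c3)c3nccnc3c2)C1`, differs from compound 2 by 1-acetylpyrrolidin-3-yl in place of (1-methyl-1H-pyrazol-4-yl)methyl on an amide-type nitrogen. Within the data shown here, no measured step exists for this change, so the step from compound 2 to compound 3 is expected to stay within the scatter, with no clear direction, giving a 1.1-fold lower number from compound 2 to compound 3 (0.04 log units; within the scatter). Compound 3 is therefore estimated at 70000 nM in this assay, expected between 25000 nM and 200000 nM.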

Compound 3, half-maximal inhibitory concentration: > 100000 nM
Compound 3 ended at the assay's limit; the forecaster's own chance of this, stated with the estimate: 35%; middle value at least 1.4-fold (0.15 log units) from the limit.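

Putting 1-acetylpyrrolidin-3-yl on the amide-type nitrogen gives an at least 1.3-fold higher number from compound 2 to compound 3 (0.11 log units; that floor lies within the scatter) in this assay, so this change brings no sign of a lower number. From the compounds shown here alone, the value of compound 3 is a limit of the assay, and the size of the step stays unknown. With this result, most of the compounds shown stand at the top of the range: the limit of > 100000 nM in this assay, at which 2 of the 3 values shown sit.

The compounds shown leave open whether a substituent carrying an amine or a carboxylic acid on this nitrogen would give a number clearly lower than that of compound 2.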